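Adding a methyl to the side chain of compound 2

This account rests on a few compounds, and the source may have more. Where it says the series, first, only, none or still open, it means among the compounds named here.

Measured in a functional assay on K562 cells (Homo sapiens); a higher number here means a weaker inhibitor, a lower number a stronger inhibitor:
- compound 1 `CNC(=O)Nc1ccc(C(C)C)cc1` gives 198000 nM
- compound 2 `CCNC(=O)Nc1ccc(C(C)C)cc1` gives 142000 nM

Compound 2 stands within the scatter of compound 1, so these two numbers cannot be ranked. Going by the values given here, the only measured step reads a 1.4-fold lower number from compound 1 to compound 2 (0.14 log units; within the scatter) and sets neither compound apart.

Compound 3 `CCNC(=O)Nc1ccc(C(C)CC)cc1` differs from compound 2 by methyl in place of hydrogen on a saturated chain carbon, two bonds along the chain from an aromatic carbon and the same difference, cut one bond further out, reads isopropyl to sec-butyl. It is methyl in place of hydrogen on a saturated chain carbon, two bonds along the chain from an aromatic carbon.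

The step from compound 1 to compound 2 bears on this only indirectly. It also adds a methyl in place of hydrogen on a saturated chain carbon, but that carbon is bound to an amide-type nitrogen. Among the compounds with values here, no measured step changes the isopropyl group itself, so the data offer no direct evidence at this place. With only a 1.4-fold lower number from compound 1 to compound 2 (0.14 log units; within the scatter) as a guide, no step beyond the scatter is expected in this assay for this change. The estimated step reads a 1.1-fold lower number from compound 2 to compound 3 (0.04 log units; within the scatter) and is expected to remain small. Compound 3 is expected at 130000 nM (estimated range 70000 nM to 240000 nM) once measured.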

Compound 3, half-maximal inhibitory concentration: 101000 nM
For compound 3 the middle estimate is 1.3-fold (0.11 log units) above the measured one; measured number inside the range.
By their numbers in this assay, from the lowest: compounds 3, 2 and 1 (each within the scatter of the next).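

In this assay, going by these compounds alone, this is the first step at the isopropyl group itself, and isopropyl to sec-butyl gives a 1.4-fold lower number from compound 2 to compound 3 (0.15 log units; within the scatter) and so does not set compound 3 apart from compound 2. Methyl in place of hydrogen on this saturated chain carbon, two bonds along the chain from an aromatic carbon, therefore joins the earlier methyl on the carbon bound to an amide-type nitrogen: neither single addition produces a step beyond the scatter. No measurement is available that would account for this outcome.

The compounds shown leave open whether a larger change at this place would produce a step beyond the scatter, for instance a longer chain in place of sec-butyl, a cyclohexyl group, or an amine or a carboxylic acid on the same chain carbon. On these data alone, it also remains open whether a longer chain in place of the ethyl group on the amide-type nitrogen would separate any compound from compound 2 in this assay's read-out.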